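The source may report more compounds than this note shows. Statements on the series, on what has been measured and on what is new or still open speak of the compounds shown alone.

Of the compounds shown here, two have so far been tested in a functional assay on A549 cells (Homo sapiens) for antiproliferative activity, read by MTT assay, with a stated time of 72 h; on this read-out higher numbers stand for weaker inhibition and lower numbers for stronger inhibition. Compound 1 `COc1cc2ncnc(Nc3ccc(Br)cc3)c2cc1OCCCCC(=O)Nc1ccc(S(N)(=O)=O)cc1` gives > 40000 nM, which is a limit of the assay and not a number. Compound 2 `NS(=O)(=O)c1ccc(NC(=S)Nc2ccc3ncnc(Nc4ccc(F)c(Cl)c4)c3c2)cc1` gives > 40000 nM, which is also a limit and not a number. Compound 2 therefore has no exact value, and the data so far consist of the limit of > 40000 nM in this assay, at which 2 of the 2 values shown sit.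

Compound 3 `NS(=O)(=O)c1ccc(NC(=S)Nc2ccc3ncnc(Nc4ccc(F)c(Br)c4)c3c2)cc1` differs from compound 2 in one place: bromo in place of chloro on an aromatic carbon. The exchange sits ortho to a fluoro group and meta to a large group, turning 3-chloro-4-fluorophenyl into 3-bromo-4-fluorophenyl.

Among the compounds with values here, no measured pair shows what this exchange does, so the expectation rests on compound 2 alone, and no step beyond the usual scatter is expected in this assay, in either direction. The expected change is a number no higher from compound 2 to compound 3 (the limit leaves the size open). Compound 3 is estimated at 40000 nM, with an expected range from 15000 nM to 80000 nM, and it is expected that the assay may again report only a limit.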

Compound 3, half-maximal inhibitory concentration: > 40000 nM
Compound 3 gave a limit, no number (the forecaster's own chance of this, stated with the estimate: 75%); the middle value sits exactly at the limit.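

In this assay compound 3 gives > 40000 nM as a limit of the assay and not a number. Within the data shown here, no step from bromo in place of chloro can be read between compound 2 and compound 3: the limit of > 40000 nM in this assay, at which 3 of the 3 values shown sit. The compounds shown leave open how bromo and chloro compare at this place, as none has an exact value.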